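The compounds below may be only part of what the source reports. "The series", "measured", "known", "first", "only" and "open" are said of these compounds alone.

Measured in a physicochemical assay for solubility, read by nephelometry; on this read-out lower numbers stand for lower solubility and higher numbers for higher solubility:
compound 1 `CCCCOc1nc(N)c2ncn(Cc3c(F)ccc(C)c3F)c2n1`: 50000 nM
compound 2 `CCC(Oc1nc(N)c2ncn(Cc3c(F)ccc(C)c3F)c2n1)C(F)(F)C(F)(F)F`: 25000 nM
compound 3 `CC(=O)NC(C)Oc1nc(N)c2ncn(Cc3c(F)ccc(C)c3F)c2n1`: 100000 nM

The number for compound 1 falls between the other two and within the scatter of each, with a 2.0-fold lower number from compound 1 to compound 2 (0.30 log units; within the scatter) and a 2.0-fold higher number from compound 1 to compound 3 (0.30 log units; within the scatter). The unmeasured compound 4 `CCCCOc1nc(NCc2ccccc2)c2ncn(Cc3c(F)ccc(C)c3F)c2n1` keeps the butyl on oxygen and turns the amino group into benzylamino, with benzyl in place of hydrogen on a nitrogen on an aromatic ring. Going by the values given here, no measured step touches that nitrogen. All three replace the group on the oxygen, and the widest, a 4.0-fold higher number from compound 2 to compound 3 (0.60 log units; beyond the scatter), is modest. These steps offer only a rough guide to how far the numbers move in this small set, and they say nothing direct about direction at the new place. The expectation is nonetheless a lower number, by a step comparable to that widest one, and this remains a judgement without a direct precedent here. The expected step is a 4.2-fold lower number from compound 1 to compound 4 (0.62 log units; beyond the scatter). For compound 4 the estimate is 12000 nM, with an expected range from 3000 nM to 40000 nM.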

Compound 4, solubility: 3100 nM
The estimate for compound 4 lay 3.9-fold (0.59 log units) above the measured number, and the stated range covers the measured number.
By their numbers in this assay, from the lowest: compound 4; then compounds 2, 1 and 3 (each within the scatter of the next, the first and the last beyond it).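

Benzyl in place of hydrogen on a nitrogen on an aromatic ring brings a 16-fold lower number from compound 1 to compound 4 (1.21 log units; beyond the scatter) in this assay and gives the first reading at this place. That step is larger than any step at the group on the oxygen, the widest of which is a 4.0-fold higher number from compound 2 to compound 3 (0.60 log units; beyond the scatter) in the same assay, so in this small set the nitrogen carries the largest single move. Nothing available bears on why the number falls at this nitrogen.

As far as these compounds go, whether the fall belongs to benzyl itself or would follow any replacement of that hydrogen stays open, and a methyl, a 2-phenylethyl or a benzyl bearing a carboxylic acid could separate these. Also open, from the compounds shown here alone, is whether benzylamino would bring a similar step with 1-acetamidoethyl rather than butyl on the oxygen.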